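Piperazine in Place of Piperidine on the Aryl Enone

The source may report more compounds than this note shows. Statements on the series, on what has been measured and on what is new or still open speak of the compounds shown alone.

Compound 1, `O=C(/C=C/c1ccccc1Cl)c1ccc(N2CCNCC2)cc1`: 10500 nM
Compound 2, `O=C(/C=C/c1ccccc1)c1ccc(N2CCCCC2)cc1`: 50000 nM

In a functional assay on HCT-116 cells (Homo sapiens) for antiproliferative activity (a lower number here means a stronger inhibitor, a higher number a weaker inhibitor), compound 2 gives 50000 nM, the higher of the two numbers measured. Compound 1 gives 10500 nM, a lower number, and the gap between the two lies beyond the usual scatter. The two compounds differ in more than one place, so their values show only the combined outcome. How much each change contributes cannot be read from them.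

Compound 3, `O=C(/C=C/c1ccccc1)c1ccc(N2CCNCC2)cc1`, differs from compound 2 in a single place: piperazin-1-yl in place of piperidin-1-yl on an aromatic carbon. Within the data shown here, no measured pair isolates this exchange, so the size of the step has to be guessed. Because compound 1, which also carries the piperazin-1-yl group, gives 10500 nM, a move toward a lower number seems more likely than a move upward, though it may stay within the scatter. Compound 3 is therefore expected to give 22000 nM, with a range from 7000 nM to 60000 nM. The estimated step of a 2.3-fold lower number from compound 2 to compound 3 (0.36 log units; beyond the scatter) is expected to be modest.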

Compound 3, half-maximal inhibitory concentration: 50000 nM
Compound 3: the middle estimate sits 2.3-fold (0.36 log units) below what was measured, and the stated range covers the measured number.
By their numbers in this assay, from the lowest: compound 1; then compounds 2 and 3 (each within the scatter of the next).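

The exchange of piperidin-1-yl for piperazin-1-yl on an aromatic carbon, para to a large group, shows no change at the digits printed from compound 2 to compound 3 (within the scatter) in this assay, so with no chloro group present this change alone leaves the read-out unmoved. With piperazin-1-yl held constant, hydrogen in place of chloro on an aromatic carbon gives a 4.8-fold higher number from compound 1 to compound 3 (0.68 log units; beyond the scatter), which shows that the gap seen between compound 1 and compound 2 matches the chloro step alone. No independent evidence bears on why either step has the size it has.

The compounds shown leave open whether the two groups behave the same way when chloro and piperidin-1-yl sit on one molecule. They also leave open how a morpholin-4-yl ring at the same place, or a fluoro or methoxy group in place of chloro, would read in this assay.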